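This account rests on a few compounds, and the source may have more. Where it says the series, first, only, none or still open, it means among the compounds named here.

Compound 3, `COc1ccc(/C=C\C(=O)O)c(OCc2cn(-c3ccc(CO)cc3)nn2)c1CC=C(C)C`, belongs to a small set built on one shared core. Compound 1, `COc1ccc(/C=C\C(=O)O)c(OCc2cn(-c3ccccc3I)nn2)c1CC=C(C)C`, has in a functional assay on PC-3 cells (Homo sapiens) for cytotoxicity, read by MTT assay, with a stated time of 24 h (a higher number here means a weaker inhibitor, a lower number a stronger inhibitor), the entry "not determined" (no result reported). Compound 2, `COc1ccc(/C=C\C(=O)O)c(OCc2cn(-c3ccccc3)nn2)c1CC=C(C)C`, gives 35000 nM in this assay, and compound 3 gives 28300 nM. Compound 3 thus holds the lower of the two numbers available, but the step of a 1.2-fold lower number from compound 2 to compound 3 (0.09 log units; within the scatter) lies within the scatter, so the two compounds cannot be told apart on these data.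

Compound 4, `COc1ccc(/C=C\C(=O)O)c(OCc2cn(-c3ccccc3F)nn2)c1CC=C(C)C`, is the next compound in line. Its change from compound 3 is 2-fluorophenyl in place of 4-(hydroxymethyl)phenyl on an aromatic nitrogen. Within the data shown here, only one measured step bears on this position on the aromatic nitrogen, namely the one from compound 2 to compound 3, and that step stayed within the scatter. Nothing in the set suggests that a group on this ring moves the number much, so the step of a 1.2-fold higher number from compound 3 to compound 4 (0.07 log units; within the scatter) is expected to fall within the scatter as well. On that basis compound 4 is estimated to give 33000 nM in this assay, with a range from 15000 nM to 70000 nM.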

Compound 4, half-maximal inhibitory concentration: 24200 nM
For compound 4 the middle estimate is 1.4-fold (0.13 log units) above the measured one; low and high end bracket the measured number.
By their numbers in this assay, from the lowest: compounds 4, 3 and 2 (each within the scatter of the next).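

In this assay, putting 2-fluorophenyl in place of 4-(hydroxymethyl)phenyl on the aromatic nitrogen gives a 1.2-fold lower number from compound 3 to compound 4 (0.07 log units; within the scatter) and thus adds a second step at this position that stays within the scatter, even though the change removes the hydroxymethyl group with its hydrogen-bond donor and acceptor. Fluoro in place of hydrogen on an aromatic carbon of the phenyl gives a 1.4-fold lower number from compound 2 to compound 4 (0.16 log units; within the scatter) and likewise leaves the compounds indistinguishable, so among compounds 2, 3 and 4 neither substituent separates one compound from another.

The compounds shown leave open whether an amine or a carboxylic acid on this phenyl ring would produce a step beyond the scatter. They also leave open what a longer chain in place of the phenyl ring would do. No evidence is available here that bears on these results.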